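This account rests on a few compounds, and the source may have more. Where it says the series, first, only, none or still open, it means among the compounds named here.

Measured so far in a functional assay on A549 cells (Homo sapiens) for cytotoxicity, read by MTT assay, with a stated time of 72 h; a lower number here means a stronger inhibitor, a higher number a weaker inhibitor:
- compound 1 `CNC(=O)c1cc(Oc2ccc(C3=NNC(c4cccc(Br)c4)C3)cc2)ccn1`: 2840 nM
- compound 2 `CNC(=O)c1cc(Oc2ccc(C3=NNC(c4ccc(F)cc4)C3)cc2)ccn1`: 15100 nM

Compound 2, at 15100 nM, holds the higher of the two numbers and is the weaker inhibitor of the pair. Compound 3 `CNC(=O)c1cc(Oc2ccc(C3=NN(C(N)=S)C(c4ccc(F)cc4)C3)cc2)ccn1` changes compound 2 at one place: a group of 3 heavy atoms (1 carbon, 1 nitrogen, 1 sulfur; no ring) in place of a hydrogen atom, on an amine nitrogen in a ring. For the measured compounds named here, no measured compound carries anything but hydrogen on this amine nitrogen in a ring, so no measured step speaks directly to the change. Going by the values given here, the one step available, a 5.3-fold higher number from compound 1 to compound 2 (0.73 log units; beyond the scatter), is modest and was made on a saturated ring carbon. It offers only a rough scale. On that scale, a step of similar size is expected in this assay, tentatively toward a lower number, although the data do not settle the direction. The estimated step is a 2.5-fold lower number from compound 2 to compound 3 (0.40 log units; beyond the scatter). For compound 3 the expected value is 6000 nM, with an estimated range of 1500 nM to 24000 nM.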

Compound 3, half-maximal inhibitory concentration: 19400 nM
For compound 3 the middle estimate is 3.2-fold (0.51 log units) below the measured one, within the range that was stated.
By their numbers in this assay, from the lowest: compound 1; then compounds 2 and 3 (each within the scatter of the next).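

In this assay the first substitution seen on this amine nitrogen in a ring gives a 1.3-fold higher number from compound 2 to compound 3 (0.11 log units; within the scatter) and so leaves the number of compound 2 unchanged within the scatter. For the compounds shown here, a group of 3 heavy atoms can therefore stand here in place of a hydrogen atom with no measurable change in this assay, whereas the one earlier step, made on a saturated ring carbon, lay beyond the scatter. Nothing at hand explains why this change leaves the number flat.

From the compounds shown here alone, whether a different group on this nitrogen, such as an acetyl group, a urea with oxygen in place of sulfur, or a longer chain, would move the number remains open. Going by these compounds, it is also open whether the same group would read alike on compound 1 at 2840 nM, which carries 3-bromophenyl in place of 4-fluorophenyl.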